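The compounds below may be only part of what the source reports. "The series", "measured", "known", "first", "only" and "open" are said of these compounds alone.

Compound 3 `O=C1c2sccc2N(Cc2ccc(Cl)cc2)S(=O)(=O)N1Cc1ccccc1` is the only one of the three measured compounds that gives a number in an ADME assay on MT4 cells (Homo sapiens) for cytotoxicity, read by MTT assay, with a stated time of 4 days; a higher number here means that more compound is tolerated, a lower number that less compound is tolerated: compound 3 gives 8200 nM. Compound 1 `N#Cc1ccccc1CN1c2ccsc2C(=O)N(Cc2ccccc2)S1(=O)=O` gives > 305000 nM, which is a limit of the assay and not a number. Compound 2 `N#Cc1cccc(CN2c3ccsc3C(=O)N(Cc3ccccc3)S2(=O)=O)c1` likewise gives > 305000 nM, again a limit. Compound 4 `N#Cc1ccc(CN2c3ccsc3C(=O)N(Cc3ccccc3)S2(=O)=O)cc1` has not yet been measured in this assay. It differs from compound 3 by cyano in place of chloro on an aromatic carbon. The measured steps that bear on this change are an at least 37-fold lower number from compound 1 to compound 3 (1.57 log units; beyond the scatter) and an at least 37-fold lower number from compound 2 to compound 3 (1.57 log units; beyond the scatter), both large and both running from a cyanophenyl compound to the chlorophenyl compound 3; the step that the two limits leave unreadable from compound 1 to compound 2 cannot be read. Because compounds 1 and 2 both sit at the limit of > 305000 nM in this assay, at which 2 of the 3 values shown sit, compound 4, which restores a cyano group, is expected to move in the opposite direction, by a large step, a 24-fold higher number from compound 3 to compound 4 (1.39 log units; beyond the scatter), with a fair chance that this assay again reports only a limit. Compound 4 is therefore estimated at 200000 nM, in a range from 50000 nM to 500000 nM.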

Compound 4, half-maximal cytotoxic concentration: 8500 nM
Beside the measured number, compound 4's estimate is 24-fold (1.37 log units) above it, outside the stated range (below it).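

In this assay, exchanging chloro for cyano on this aromatic carbon, para to a large group, gives a 1.0-fold higher number from compound 3 to compound 4 (0.02 log units; within the scatter), so the two groups cannot be told apart at this place. The earlier compounds shown here had suggested that the cyano group went with the limit, but the position of the cyano group on the phenyl ring is what separates these compounds: 4-cyanophenyl in place of 3-cyanophenyl gives an at least 35-fold lower number from compound 2 to compound 4 (1.55 log units; beyond the scatter), and 4-cyanophenyl in place of 2-cyanophenyl gives an at least 35-fold lower number from compound 1 to compound 4 (1.55 log units; beyond the scatter). Both steps start from a limit of the assay and not from a number: the limit of > 305000 nM in this assay, at which 2 of the 4 values shown sit.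

Going by these compounds, how far compounds 1 and 2 lie past that limit remains open, so the full size of both steps is unknown. Also open, on these data alone, is whether an amine, a carboxylic acid or a methoxy group at this place would match chloro and cyano.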